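This account rests on a few compounds, and the source may have more. Where it says the series, first, only, none or still open, it means among the compounds named here.

Measured so far in a functional assay, with a stated time of 20 min, tested at 20 uM; on this read-out lower numbers stand for a weaker effect and higher numbers for a stronger effect at the one concentration tested:
compound 1, `COc1cc(/C=C/C(=O)C2=C(/C=C/c3ccc(O)c(OC)c3)NC(=O)NC2c2ccccc2)ccc1O`, gives 38.2%
compound 2, `COc1cc(/C=C/C(=O)C2=C(/C=C/c3ccc(O)c(OC)c3)NC(=O)NC2c2ccc(N(C)C)cc2)ccc1O`, gives 48%
compound 3, `COc1cc(/C=C/C(=O)C2=C(/C=C/c3ccc(O)c(OC)c3)NC(=S)NC2c2ccccc2)ccc1O`, gives 38%

All three numbers sit close together. The number for compound 3 is the smallest of the three, but its gaps to compound 1 and to compound 2 both lie within the usual scatter, so no order among them can be read from these data.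

Compound 4, `COc1cc(/C=C/C(=O)C2=C(/C=C/c3ccc(O)c(OC)c3)NC(=S)NC2c2ccccc2Cl)ccc1O`, has not yet been measured. It differs from compound 3 in one place: chloro in place of hydrogen on an aromatic carbon. The chloro enters on an aromatic carbon of a six-membered aromatic ring of carbon only, ortho to a large group; read one bond further out, phenyl becomes 2-chlorophenyl.

Within the data shown here, only one measured step exists, a number 9.8 percentage points higher from compound 1 to compound 2 (within the scatter), and it concerns a different substituent at a different position on that same ring. It does not bear directly on a chloro entering here, but it shows that a change on this ring left the read-out within the scatter. Among the measured compounds shown here, no step with a chloro, at any position, has been measured.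

On that basis no movement beyond the scatter is expected for compound 4: the estimated step is a number 2 percentage points higher from compound 3 to compound 4 (within the scatter), and compound 4 is expected to give about 40%, with a range from 27% to 53%.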

Compound 4, a percentage reported as activity, at one concentration (the size of the read-out at that concentration, not a potency): 56.6%
For compound 4 the middle estimate is 16.6 percentage points below the measured one; the measured number lies above the stated range.
By their numbers in this assay, from the lowest: compounds 3, 1, 2 and 4 (each within the scatter of the next, the first and the last beyond it).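

In this assay, chloro in place of hydrogen on an aromatic carbon, ortho to a large group, gives a number 18.6 percentage points higher from compound 3 to compound 4 (beyond the scatter). This shows that a single-atom change on this ring can move the read-out beyond the scatter, which the earlier step on the same ring, a number 9.8 percentage points higher from compound 1 to compound 2 (within the scatter), did not show, though that step concerned a different group at a different position on a different core. No measurement at hand accounts for the change from phenyl to 2-chlorophenyl, and the result gives the size of the effect at one concentration, not a potency.

Still open, on these data alone, is whether this step belongs to chloro itself or to any group at this place, a question that fluoro, bromo, methyl or methoxy on the same carbon would address, as would chloro moved elsewhere on the ring. Also open, as far as these compounds go, is whether 2-chlorophenyl on the core of compound 1 would give a step of similar size, or whether this one holds only on the core of compound 3.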